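Swapping a phenyl for an open ether chain

This account rests on a few compounds, and the source may have more. Where it says the series, first, only, none or still open, it means among the compounds named here.

Compound 1 `Cc1cccc([C@@H](O)C(=O)N2N=CC[C@H]2C(=O)NCc2cc(Cl)ccc2-n2cnnn2)c1`, compound 2 `O=C(NCc1cc(Cl)ccc1-n1cnnn1)[C@@H]1[C@H]2C[C@H]2CN1C(=O)[C@H](O)c1ccccc1` and compound 3 `O=C(NCc1cc(Cl)ccc1-n1cnnn1)[C@@H]1[C@@H]2C[C@@H]2CN1C(=O)[C@H](O)c1ccccc1` have all been measured in a functional assay on a cell-free system (plasma, Homo sapiens), with a stated time of 3 min; on this read-out lower numbers stand for stronger inhibition and higher numbers for weaker inhibition. There compound 1 gives 830 nM, compound 2 gives 960 nM and compound 3 gives 700 nM. Compound 2 therefore stands level with the other two, within the usual scatter of repeat measurements.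

Among the measured compounds shown here, the only measured step between a matched pair is a 1.4-fold lower number from compound 2 to compound 3 (0.14 log units; within the scatter). It comes with the fact that compounds 2 and 3 differ only in the configuration as drawn, so it speaks to drawn configuration and not to the group that changes next.

Compound 4 `CC(C)(C)OC[C@@H](O)C(=O)N1C[C@@H]2C[C@@H]2[C@H]1C(=O)NCc1cc(Cl)ccc1-n1cnnn1` makes a different kind of change: (tert-butoxy)methyl in place of phenyl on a saturated chain carbon bound to a carbonyl carbon and an oxygen on a saturated carbon. In words, (tert-butoxy)methyl stands in place of phenyl on a saturated chain carbon bound to a carbonyl carbon and an oxygen on a saturated carbon.

Compound 1, compound 2 and compound 3 all keep an aromatic ring of carbon only at that place, so none of them shows what losing it does. The measured step therefore gives no direct guide to size. A modest move towards weaker inhibition in this assay is expected, though with wide uncertainty.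

The expected change is a 2.6-fold higher number from compound 2 to compound 4 (0.42 log units; beyond the scatter).

For compound 4 the estimated value is 2500 nM, with a range from 700 nM to 9000 nM.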

Compound 4, half-maximal inhibitory concentration: 570 nM
The estimate for compound 4 lay 4.4-fold (0.64 log units) above the measured number; the measured number lies below the stated range.
By their numbers in this assay, from the lowest: compounds 4, 3, 1 and 2 (each within the scatter of the next).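

In this assay, (tert-butoxy)methyl in place of phenyl on a saturated chain carbon bound to a carbonyl carbon and an oxygen on a saturated carbon gives a 1.7-fold lower number from compound 2 to compound 4 (0.23 log units; within the scatter). Among the compounds shown here, compound 1, compound 2 and compound 3 all keep an aromatic ring of carbon only at this place, so this pair is the first to show that the ring can be replaced by an open chain with the same count of heavy atoms while the number stays level with that of compound 2. What is known about these compounds offers no explanation for this result, as the only available fact concerns drawn configuration and not this change of group.

The result does not separate the contribution of the ether oxygen from that of the branched tert-butyl end, which a smaller methoxymethyl group or an all-carbon 3,3-dimethylbutyl group at the same place could help to tell apart. It also leaves open whether the same swap would stay level on the core of compound 1 or with the drawn configuration of compound 3.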